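Flavanone series: pentyl to hydrogen on the aryl ether oxygen

The compounds below may be only part of what the source reports. "The series", "measured", "known", "first", "only" and "open" are said of these compounds alone.

Of the compounds shown here, three have been measured in a functional assay on MCF7 cells (Homo sapiens) for antiproliferative activity, read by sulforhodamine B assay, with a stated time of 72 h; on this read-out lower numbers stand for stronger inhibition and higher numbers for weaker inhibition. Compound 1 `C=CCOc1ccc([C@@H]2CC(=O)c3c(OC)cc(OCC=C)c(CC=C(C)C)c3O2)cc1` gives 5.2 ug/mL. Compound 2 `COc1cc(OC(C)=O)c(CC=C(C)C)c2c1C(=O)C[C@@H](c1ccc(OC(C)=O)cc1)O2` gives 16.9 ug/mL. Compound 3 `CCCCCOc1ccc([C@@H]2CC(=O)c3c(OC)cc(OCCCCC)c(CC=C(C)C)c3O2)cc1` gives 7.1 ug/mL, the second highest of the three numbers; its nearest neighbour is compound 1, within the scatter, while compound 2 stands beyond the scatter with the higher number. Among the compounds with values here, no pair among the measured compounds differs in only one place, so no single-change step is available as a guide.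

Compound 4 `CCCCCOc1cc(OC)c2c(c1CC=C(C)C)O[C@H](c1ccc(O)cc1)CC2=O` has not yet been measured. It differs from compound 3 in one place: hydrogen in place of pentyl on an oxygen on an aromatic ring, that is, pentyloxy to hydroxy, or 4-(pentyloxy)phenyl to 4-hydroxyphenyl, on the oxygen on an aromatic ring whose other neighbour is aromatic carbon. The chains on the other aromatic oxygen and the rest of the core are unchanged.

With no measured step of this kind in the series, the step of a 1.3-fold higher number from compound 3 to compound 4 (0.10 log units; within the scatter) is expected to stay within the usual scatter, with at most a slight move toward the higher numbers. Compound 4 is therefore expected to give 9 ug/mL, with a range from 4 ug/mL to 20 ug/mL.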

Compound 4, concentration for 50% inhibition: 8.3 ug/mL
Compound 4: the middle estimate sits 1.1-fold (0.04 log units) above what was measured; the range from low to high includes it.
By their numbers in this assay, from the lowest: compounds 1, 3 and 4 (each within the scatter of the next); then compound 2.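

In this assay, hydrogen in place of pentyl on an oxygen on an aromatic ring gives a 1.2-fold higher number from compound 3 to compound 4 (0.07 log units; within the scatter) and this lies within the scatter. Within the data shown here, this is the first single-change step, and it shows that pentyloxy and hydroxy at this position cannot be told apart on this read-out, although the result holds for this one pair only, with the pentyl chain on the other aromatic oxygen present in both compounds. No measurement at hand bears on why the step is this small.

Open, going by these compounds, is whether a longer chain such as octyl, or a chain ending in an amine or a carboxylic acid, on this oxygen would also stay within the scatter. Also open, on these data alone, is whether hydrogen in place of pentyl on the other aromatic oxygen would give a step of similar size.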